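Ortho chloro on the biaryl linker of an indazole acid

This account rests on a few compounds, and the source may have more. Where it says the series, first, only, none or still open, it means among the compounds named here.

Compound 1 `CNc1ccc2[nH]nc(C(=O)O)c2c1`, the bare core, reaches only the limit > 30000 nM in an assay on isolated protein for inhibition of 2-Hydroxyacid oxidase 1 (Homo sapiens), with stated times of 30 min and 15 min; a lower number here means a stronger inhibitor, a higher number a weaker inhibitor. Among the compounds with values here, compound 2 `CN(C)c1noc(-c2cccc(CNc3ccc4[nH]nc(C(=O)O)c4c3)c2)n1` gives 170 nM in this assay, the only number obtained. The other value shown, that of compound 1, is the limit (the limit of > 30000 nM in this assay, at which 1 of the 2 values shown sits). Compound 3 `CN(C)c1noc(-c2cccc(CNc3ccc4[nH]nc(C(=O)O)c4c3)c2Cl)n1` differs from compound 2 by chloro in place of hydrogen on an aromatic carbon. Within the data shown here, no measured step guides this change, so the expected step from compound 2 to compound 3 is a 1.2-fold higher number from compound 2 to compound 3 (0.07 log units; within the scatter), within the usual scatter. Compound 3 is estimated at 200 nM, between 60 nM and 700 nM.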

Compound 3, half-maximal inhibitory concentration: 180 nM
Estimate against measurement, compound 3: 1.1-fold (0.05 log units) above; the range from low to high includes it.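

A step of a 1.1-fold higher number from compound 2 to compound 3 (0.02 log units; within the scatter) in this assay comes with chloro in place of hydrogen on the aromatic carbon ortho to the 3-(dimethylamino)-1,2,4-oxadiazol-5-yl group. Within the data shown here, this carbon, ortho to a large group, therefore accepts a chlorine atom with no readable difference in inhibition, which the earlier compounds, with no single-place step between them, could not show. Nothing given here bears on the reason for this result.

Going by these compounds, whether a methoxy group, an amine or a nitrile on this carbon would read the same remains open.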